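The source may report more compounds than this note shows. Statements on the series, on what has been measured and on what is new or still open speak of the compounds shown alone.

Compound 1, `CC1CCN(C2CCN(S(=O)(=O)c3ccc(C(C)(C)C)cc3)CC2)CC1`, in an ADME assay on HCT-116 cells (Homo sapiens) for cytotoxicity, read by CellTiter-Glo, with a stated time of 72 h; on this read-out lower numbers stand for stronger inhibition and higher numbers for weaker inhibition: > 5000 nM, which is a limit of the assay rather than a number.
Compound 2, `CCc1ccc(S(=O)(=O)N2CCC(N3CCC(C)CC3)CC2)cc1`, in this assay: > 5000 nM, again a limit.
Compound 3, `CCCOc1ccc(S(=O)(=O)N2CCC(N3CCC(C)CC3)CC2)cc1`, in this assay: > 5000 nM, again a limit.

All three measured compounds share one core and differ only in the group on the aromatic carbon of the outer ring: tert-butyl in compound 1, ethyl in compound 2, propoxy in compound 3. Compound 3 therefore stands with its two neighbours: only a limit is known for it, and no number.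

The three steps among the measured compounds are a step that the two limits leave unreadable from compound 1 to compound 2, a step that the two limits leave unreadable from compound 1 to compound 3 and a step that the two limits leave unreadable from compound 2 to compound 3. None of them can be read, because every value sits at the limit of > 5000 nM in this assay, at which 3 of the 3 values shown sit.

Compound 4, `CC1CCN(C2CCN(S(=O)(=O)c3ccc(-c4ccccc4F)cc3)CC2)CC1`, has not yet been measured. It differs from compound 3 by 2-fluorophenyl in place of propoxy on an aromatic carbon. Among the compounds with values here, the steps that bear on this change are the three above, and all of them are unreadable, so no size and no direction can be drawn from them for this assay. The plain expectation is that compound 4 also falls at or near the limit.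

Compound 4 is expected at 8000 nM, within a range from 2000 nM to 30000 nM. This estimate corresponds to an expected step that the limit leaves unreadable from compound 3 to compound 4.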

Compound 4, half-maximal inhibitory concentration: > 5000 nM
Compound 4 was reported as a limit; the forecaster's own chance of this, stated with the estimate: 70%; the middle value does not contradict the limit.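

The steps joining compound 4 to compound 1, compound 2 and compound 3 cannot be read, because all four compounds give a limit of the assay and no number: (the limit of > 5000 nM in this assay, at which 4 of the 4 values shown sit). The compounds shown leave open how these four differ in this assay, and whether any group at this place on the outer ring changes the read-out at all.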